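Sulfonyl aryl swap on the shared core

The source may hold more compounds than are shown below. What is called first, only, known or untested is meant among the compounds shown, and "the series" means these compounds.

compound 1 `C=CCNC(=O)n1c(-c2ccc(OC)cc2)cc(=O)c2c(OC)cc(OC)cc21` — > 20000 nM
compound 2 `COc1ccc(-c2cc(=O)c3c(OC)cc(OC)cc3n2S(=O)(=O)c2cccc([N+](=O)[O-])c2)cc1` — > 39600 nM

In a functional assay on HepG2 cells (Homo sapiens) for antiproliferative activity, with a stated time of 72 h (on this read-out lower numbers stand for an effect already at smaller amounts and higher numbers for an effect only at larger amounts of compound), compound 1 gives > 20000 nM, which is a limit of the assay and not a number. In this assay compound 2 gives > 39600 nM, again a limit rather than a number. Compound 1 sits at the limit of > 20000 nM in this assay, at which 1 of the 2 values shown sits. Compound 2 sits at the limit of > 39600 nM in this assay, at which 1 of the 2 values shown sits, so its standing within the pair is a limit only, with no numeric position. Compound 3 `COc1ccc(-c2cc(=O)c3c(OC)cc(OC)cc3n2S(=O)(=O)c2ccc(C#N)cc2)cc1` is not yet measured in this assay; it differs from compound 2 by 4-cyanophenyl in place of 3-nitrophenyl on a sulfonyl sulfur. For the measured compounds named here, no step between measured compounds exists in this set, so nothing here calibrates a change of the aryl group on the sulfonyl sulfur. With both measured values at limits, no move beyond the scatter is expected in this assay in either direction. Compound 3 is therefore expected to give about 40000 nM in this assay, estimated between 10000 nM and 150000 nM, most likely reported as a limit. The expected step is a step that the limit leaves unreadable from compound 2 to compound 3, nothing beyond scatter.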

Compound 3, half-maximal effective concentration: > 17200 nM
Compound 3 was reported as a limit; the forecaster's own chance of this, stated with the estimate: 80%; the middle value does not contradict the limit.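

In this assay compound 3 gives > 17200 nM, a limit and not a number, so the steps linking it to compound 1 and compound 2 cannot be read. The compounds shown leave open whether changing the group on the aromatic nitrogen alters the read-out at all.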